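Series notes: aryl swap at the thiophene-adjacent sulfur position

The compounds below may be only part of what the source reports. "The series", "measured", "known", "first", "only" and "open" are said of these compounds alone.

Of the compounds shown here, three of a shared core have been measured in a functional assay on L1210 cells (Mus musculus) for antiproliferative activity; a lower number here means a stronger inhibitor, a higher number a weaker inhibitor. Compound 1 `COc1cc(C(=O)c2sc(-c3ccc(C)cc3)cc2N)cc(OC)c1OC` gives 18 nM, compound 2 `COc1cc(C(=O)c2sc(-c3ccccc3)cc2N)cc(OC)c1OC` gives 11 nM, and compound 3 `COc1ccc(-c2cc(N)c(C(=O)c3cc(OC)c(OC)c(OC)c3)s2)cc1` gives 45 nM. Compound 3 stands at the highest number of the three: the step of a 2.5-fold higher number from compound 1 to compound 3 (0.40 log units; beyond the scatter) and the step of a 4.1-fold higher number from compound 2 to compound 3 (0.61 log units; beyond the scatter) are both beyond the scatter, while the step of a 1.6-fold lower number from compound 1 to compound 2 (0.21 log units; within the scatter) is within it.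

Compound 4 `COc1cc(C(=O)c2sc(-c3ccccc3Cl)cc2N)cc(OC)c1OC` is not yet measured. Relative to compound 3 the change is 2-chlorophenyl in place of 4-methoxyphenyl on an aromatic carbon. The 4-methoxyphenyl is the group that accompanies the highest number in the series, and its removal alone, judged from the step of a 4.1-fold higher number from compound 2 to compound 3 (0.61 log units; beyond the scatter) read in reverse, points toward a lower number. Within the data shown here, no measured step tells what the 2-chlorophenyl itself does, so the size of that part is unknown. On balance a lower number is expected for compound 4 in this assay, with the step of a 2.3-fold lower number from compound 3 to compound 4 (0.35 log units; beyond the scatter) as the expectation. The estimate for compound 4 is 20 nM, within the range 7 nM to 60 nM.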

Compound 4, half-maximal inhibitory concentration: 20 nM
Beside the measured number, compound 4's estimate shows no gap at the digits printed; measured number inside the range.
By their numbers in this assay, from the lowest: compounds 2, 1 and 4 (each within the scatter of the next); then compound 3.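

In this assay the step of a 2.3-fold lower number from compound 3 to compound 4 (0.35 log units; beyond the scatter) shows that a substituted phenyl on this aromatic carbon next to the ring sulfur need not carry the high number of compound 3. Chloro in place of hydrogen gives a 1.8-fold higher number from compound 2 to compound 4 (0.26 log units; within the scatter) and 2-chlorophenyl in place of 4-methylphenyl gives a 1.1-fold higher number from compound 1 to compound 4 (0.05 log units; within the scatter) and both steps lie within the scatter, so compounds 1, 2 and 4 have no order among them and, of the four compounds, only compound 3 stands apart from all the others. Nothing at hand bears on the cause of these steps.

Still open, on these data alone, is whether the high number follows the methoxy group itself or would also appear with an ethoxy group, an amine or a carboxylic acid on the phenyl ring. The compounds shown also leave open whether chloro keeps this standing elsewhere on that ring.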